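The source may report more compounds than this note shows. Statements on the series, on what has been measured and on what is new or still open speak of the compounds shown alone.

Measured compounds:
compound 1, `C=CCOC(=O)CC1C(C(=O)OCC=C)=C(N)Oc2ccc(-c3cc(OC)cc(OC)c3)cc21`, 4700 nM
compound 2, `CCOC(=O)CC1C(C(=O)OCC)=C(N)Oc2ccc(-c3ccc(F)cc3)cc21`, 72100 nM
compound 3, `C#CCOC(=O)CC1C(C#N)=C(N)Oc2ccc(-c3cccc(N)c3)cc21`, 43900 nM

The read-out behind these numbers is a functional assay on HL-60 cells (Homo sapiens) for cytotoxicity, read by CellTiter-Blue, with a stated time of 48 h (a higher number here means a weaker inhibitor, a lower number a stronger inhibitor), a measure of how strongly a compound holds back the growth of a leukaemia cell line. Among the three compounds measured, compound 2 gives the highest number in this assay, which means it is the weakest inhibitor of the three in this set. Its nearest neighbour is compound 3, whose number is lower by an amount that stays within the usual scatter, so the two cannot be told apart. Compound 1 lies furthest away, with a number lower by a margin well beyond the scatter.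

The next compound, compound 4, `CCOC(=O)CC1C(C(=O)OCC)=C(N)Oc2ccc(-c3ccc(N)cc3)cc21`, differs from compound 2 in one place: amino in place of fluoro on an aromatic carbon. Going by the values given here, no pair of measured compounds differs by exactly this change, so there is no measured step to lean on. Among the compounds with values here, the change is small in size, and the only other amino-bearing compound, compound 3, sits within the scatter of compound 2. The expectation is therefore a step of a 1.4-fold lower number from compound 2 to compound 4 (0.16 log units; within the scatter) that stays within the scatter, with no clear direction. Compound 4 is expected to give about 50000 nM, in a range from 15000 nM to 150000 nM.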

Compound 4, half-maximal inhibitory concentration: 22300 nM
For compound 4 the middle estimate is 2.2-fold (0.35 log units) above the measured one; the measured number falls inside the stated range.
By their numbers in this assay, from the lowest: compound 1; then compounds 4, 3 and 2 (each within the scatter of the next, the first and the last beyond it).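

In this assay, going by these compounds alone, the change from 4-fluorophenyl to 4-aminophenyl gives a 3.2-fold lower number from compound 2 to compound 4 (0.51 log units; beyond the scatter) and this is the only step in the set that can be read in a single place. It shows that this position, on an aromatic carbon and para to a large group, is not silent: exchanging one heavy atom, with the rest of the molecule left as it was, moves the number by more than repeat measurements would. The step is modest, and nothing measured on these compounds explains it.

On these data alone, whether a hydroxyl group, a methoxy group or a carboxylic acid at the same position would move the number further remains open, as does the effect of placing the amino group elsewhere on the ring. Also open, as far as these compounds go, is whether the same exchange would give a similar step alongside the allyl esters of compound 1 or the nitrile of compound 3; these compounds differ from compound 4 in more than one place, so they cannot answer this.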